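The compounds below may be only part of what the source reports. "The series", "measured", "known", "first", "only" and "open" are said of these compounds alone.

Measured so far:
- compound 1 `CC[C@@H]1C(=O)N(C)c2cnc(Nc3ccc(S(=O)(=O)Nc4ccccc4)cc3)nc2N1C1CCCC1` gives 54.4 nM
- compound 2 `CC[C@@H]1C(=O)N(C)c2cnc(Nc3ccc(S(=O)(=O)NCCCO)cc3)nc2N1C1CCCC1` gives 8.16 nM
- compound 3 `CC[C@@H]1C(=O)N(C)c2cnc(Nc3ccc(S(N)(=O)=O)cc3)nc2N1C1CCCC1` gives 10.2 nM

In an assay for inhibition of serine/threonine-protein kinase PLK2 (Homo sapiens), read by FRET and Z'-LYTE, with a stated time of 1 h (a lower number here means a stronger inhibitor, a higher number a weaker inhibitor), compound 3 stands second highest of the three numbers. Its nearest neighbour is compound 2, a step of a 1.3-fold higher number from compound 2 to compound 3 (0.10 log units; within the scatter), and its furthest is compound 1, a step of a 5.3-fold lower number from compound 1 to compound 3 (0.73 log units; beyond the scatter). Compound 4 `CC[C@@H]1C(=O)N(C)c2cnc(Nc3ccc(S(=O)(=O)NCCO)cc3)nc2N1C1CCCC1` has not been measured. It differs from compound 3 by 2-hydroxyethyl in place of hydrogen on a sulfonamide nitrogen. Among the compounds with values here, two measured steps bear on this. The closest is the comparison of compound 2 with compound 3, where a 1.3-fold higher number from compound 2 to compound 3 (0.10 log units; within the scatter) separates a hydroxyalkyl group from hydrogen at the same nitrogen. The other, a 6.7-fold lower number from compound 1 to compound 2 (0.82 log units; beyond the scatter), shows that a hydroxyalkyl group and hydrogen at that nitrogen both give lower numbers than phenyl by a similar amount. Since hydrogen and 3-hydroxypropyl are indistinguishable here, the 2-hydroxyethyl group is expected to give a step of a 1.1-fold lower number from compound 3 to compound 4 (0.05 log units; within the scatter), that is, none beyond the scatter. Compound 4 is therefore estimated at 9 nM, with a range from 4 nM to 20 nM.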

Compound 4, half-maximal inhibitory concentration: 7.86 nM
Compound 4: middle estimate off by 1.1-fold (0.06 log units), on the high side; the range from low to high includes it.
By their numbers in this assay, from the lowest: compounds 4, 2 and 3 (each within the scatter of the next); then compound 1.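

In this assay, the 2-hydroxyethyl group on the sulfonamide nitrogen cannot be told from hydrogen (a 1.3-fold lower number from compound 3 to compound 4 (0.11 log units; within the scatter)), and shortening the chain from 3-hydroxypropyl leaves no readable difference either (a 1.0-fold lower number from compound 2 to compound 4 (0.02 log units; within the scatter)). The lower number relative to phenyl also holds for this shorter chain (a 6.9-fold lower number from compound 1 to compound 4 (0.84 log units; beyond the scatter)), so among the four groups at this nitrogen, only phenyl stands apart. The data shown offer no explanation for this flat response to hydroxyalkyl chains.

On these data alone, it remains open whether the hydroxy group itself matters, as a plain ethyl group at the same nitrogen would show. Also open, as far as these compounds go, is whether a chain longer than 3-hydroxypropyl, or one ending in an amine or a carboxylic acid, would stay level with these compounds.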